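A few compounds are considered here, and "the series" means these few. Any claim that something is new, unique, unknown or untested is made for them only; others in the source may bear on it.

Measured so far in a functional assay on HCT-116 cells (Homo sapiens) for cytotoxicity, read by scintillation counting and thymidine incorporation, with a stated time of 72 h; on this read-out lower numbers stand for stronger inhibition and higher numbers for weaker inhibition:

Compound 1, `CC=C(c1cc(OC)cc(OC)c1)c1ccc(OC)c(O)c1`, gives 30 nM.
Compound 2, `COc1cc(OC)cc(C(=CC#N)c2ccc(OC)c(O)c2)c1`, gives 2.5 nM.
Compound 3, `COc1ccc(C(=CC#N)c2cc(OC)cc(OC)c2)cc1`, gives 1.2 nM.

Compound 2 stands second highest of the three numbers. Its nearest neighbour is compound 3: a 2.1-fold lower number from compound 2 to compound 3 (0.32 log units; beyond the scatter), a modest step that comes from hydrogen in place of hydroxy on an aromatic carbon. Its furthest neighbour is compound 1: a 12-fold lower number from compound 1 to compound 2 (1.08 log units; beyond the scatter), a large step that comes from cyano in place of methyl on a double-bonded chain carbon bound to a double-bonded chain carbon.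

Compound 4, `C=C(c1cc(OC)cc(OC)c1)c1ccc(OC)c(O)c1`, is not yet measured. It differs from compound 2 as follows:

hydrogen in place of cyano on a double-bonded chain carbon bound to a double-bonded chain carbon

Going by the values given here, the one measured step that bears on this change is the step from compound 1 to compound 2, in which the cyano entered at the same place and the number fell by a 12-fold lower number from compound 1 to compound 2 (1.08 log units; beyond the scatter). Among the compounds with values here, compound 4 gives that cyano up again, though to hydrogen rather than to methyl, so no measured pair shows exactly this change. On that basis the number for compound 4 is expected to rise from compound 2, most likely by a step of about the same order as the one the cyano gave, and at least beyond the scatter: a 10-fold higher number from compound 2 to compound 4 (1.00 log units; beyond the scatter). For compound 4 the estimate in this assay is 25 nM, with a range from 8 nM to 80 nM.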

Compound 4, half-maximal inhibitory concentration: 21 nM
For compound 4 the middle estimate is 1.2-fold (0.08 log units) above the measured one; the range from low to high includes it.
By their numbers in this assay, from the lowest: compound 3; then compound 2; then compounds 4 and 1 (each within the scatter of the next).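

In this assay, the cyano group on a double-bonded chain carbon bound to a double-bonded chain carbon is now compared with hydrogen as well as methyl, and its loss to hydrogen also gives a step beyond the scatter (an 8.4-fold higher number from compound 2 to compound 4 (0.92 log units; beyond the scatter)). Hydrogen and methyl at this place cannot be told apart (a 1.4-fold lower number from compound 1 to compound 4 (0.15 log units; within the scatter)), so among the three groups compared here, the low number of compound 2 goes with cyano, while the presence of a small group in place of hydrogen brings no measurable change. No measurement shown here explains this difference.

The compounds shown leave open whether the low number is specific to cyano or could also be reached at this place with another group, such as a carboxylic acid, an amine or a longer chain. Going by these compounds, it also remains open whether a step of this size holds on the core of compound 3, which has hydrogen in place of hydroxy on an aromatic carbon.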